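The source may hold more compounds than are shown below. What is called first, only, known or untested is meant among the compounds shown, and "the series" means these compounds.

Measured compounds:
compound 1, `CCCCCCCCCCCCCC[C@H](O)[C@H](CO[Si](c1ccccc1)(c1ccccc1)C(C)(C)C)NC(=O)OC(C)(C)C`: -37.5%
compound 2, `CCCCCCCCCCCCCC[C@H](OCOC)[C@H](CO[Si](c1ccccc1)(c1ccccc1)C(C)(C)C)NC(=O)OC(C)(C)C`: -28%
compound 3, `CCCCCCCCCCCCCC[C@H](OCOC)[C@H](CN(CC)CC)NC(=O)OC(C)(C)C`: 0.84%

In a functional assay on MDA-MB-231 cells (Homo sapiens) for antiproliferative activity, read by sulforhodamine B assay, with a stated time of 48 h, tested at 10 uM (on this read-out lower numbers stand for less inhibition and higher numbers for more inhibition at the one concentration tested (going by the name of the read-out)), compound 1 gives -37.5% and compound 2 gives -28%. The change between them is hydrogen in place of methoxymethyl on an oxygen on a saturated carbon, and the step is a number 9.5 percentage points lower from compound 2 to compound 1 (within the scatter). Compound 3 stands apart, giving 0.84% in this assay; the difference between the cores of compound 3 and compound 2 is not broken down here. Compound 4, `CCCCCCCCCCCCCC[C@H](O)[C@H](CN(CC)CC)NC(=O)OC(C)(C)C`, is not yet measured. It differs from compound 3 by hydrogen in place of methoxymethyl on an oxygen on a saturated carbon, the same change as from compound 2 to compound 1. Since that change gave a step within the scatter, compound 4 is expected to lie close to compound 3, with an expected step of a number 5.8 percentage points lower from compound 3 to compound 4 (within the scatter). The estimate for compound 4 in this assay is -5%, with a range from -25% to 15%.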

Compound 4, a percentage reported as inhibition, at one concentration (the size of the read-out at that concentration, not a potency): -1.45%
Compound 4: the middle estimate sits 3.6 percentage points below what was measured; measured number inside the range.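

In this assay, putting hydrogen in place of methoxymethyl on an oxygen on a saturated carbon gave a number 2.3 percentage points lower from compound 3 to compound 4 (within the scatter). Set beside the earlier case, the change behaved alike on both cores: the same change on two cores in this assay, a number 9.5 percentage points lower (within the scatter) from compound 2 to compound 1 and a number 2.3 percentage points lower (within the scatter) from compound 3 to compound 4, 7.2 percentage points apart, within the scatter of two such steps. This shows that on these two cores the change leaves the read-out within the scatter, but it does not show that this would hold on any other core, and a single concentration gives no measure of potency.

The compounds shown leave open whether the read-out moves when the tert-butoxycarbonyl group on the nitrogen gives way to a free amine, or the alkyl chain to a shorter chain. From the compounds shown here alone, whether the same change would stay as small on such cores also remains open.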